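Working notes: dimethylamino for methoxy in the series

The compounds below may be only part of what the source reports. "The series", "measured", "known", "first", "only" and "open" are said of these compounds alone.

Measured so far in an assay on cells for inhibition of ileal sodium/bile acid cotransporter (Homo sapiens); on this read-out lower numbers stand for stronger inhibition and higher numbers for weaker inhibition:
compound 1, `CCC1(CC)CS(=O)(=O)c2ccc(N)cc2[C@@H](c2ccccc2)[C@H]1O`, gives 4000 nM
compound 2, `CCCCC1(CCCC)CS(=O)(=O)c2cc(OC)ccc2[C@@H](c2ccccc2)[C@H]1O`, gives 190 nM
compound 3, `CCCCC1(CCCC)CS(=O)(=O)c2ccc(C)cc2[C@@H](c2ccc(F)cc2)[C@H]1O`, gives 46 nM

Compound 2 holds the second highest number of the three; compound 3 stands nearer to it with a lower number, compound 1 furthest with a higher one, and both gaps lie beyond the scatter. No pair among these differs in a single place, so no measured step can guide the next change directly.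

Compound 4, `CCCCC1(CCCC)CS(=O)(=O)c2cc(N(C)C)ccc2[C@@H](c2ccccc2)[C@H]1O`, differs from compound 2 by dimethylamino in place of methoxy on an aromatic carbon. With nothing measured on this swap, only a small step is expected in this assay, with no clear direction. The step of a 1.3-fold lower number from compound 2 to compound 4 (0.10 log units; within the scatter) is estimated to stay within the usual scatter. For compound 4 a value of about 150 nM is expected, within 50 nM to 450 nM.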

Compound 4, half-maximal inhibitory concentration: 120 nM
For compound 4 the middle estimate is 1.3-fold (0.10 log units) above the measured one; the range from low to high includes it.
By their numbers in this assay, from the lowest: compound 3; then compounds 4 and 2 (each within the scatter of the next); then compound 1.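

The change from methoxy to dimethylamino gives the series its first single-place step in this assay (a 1.6-fold lower number from compound 2 to compound 4 (0.20 log units; within the scatter)). At this aromatic carbon, the two groups cannot be told apart on this read-out. No available measurement gives a reason for this result.

Going by these compounds, whether a carboxylic acid or a longer chain such as butoxy at this carbon would keep the number in the same range remains open. So does whether the same swap would read alike with the fluorophenyl group of compound 3 in place of phenyl.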